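The source may hold more compounds than are shown below. What is called first, only, known or untested is meant among the compounds shown, and "the series" means these compounds.

Compound 2 `CCCN(CCC)c1nc(C)nc2c(-c3c(C)cc(OC)cc3OC)c(C)nn12` gives 3.72 nM in an assay on cell membranes for displacement of a labelled ligand from corticotropin-releasing factor receptor 1 (Rattus norvegicus) (a higher number here means a weaker inhibitor, a lower number a stronger inhibitor), the higher of the two numbers in hand; the nearest is compound 1 `CCN(CC)c1nc(C)nc2c(-c3c(C)cc(OC)cc3OC)c(C)nn12`, which gives 1.2 nM. Among the compounds with values here, the only measured step, a 3.1-fold higher number from compound 1 to compound 2 (0.49 log units; beyond the scatter), lengthens both chains on the amino group and is modest. Compound 3 `CCCCN(CC)c1nc(C)nc2c(-c3c(C)cc(OC)cc3OC)c(C)nn12` keeps the same atoms as compound 2 but joins them differently: butyl(ethyl)amino in place of dipropylamino on an aromatic carbon. Within the data shown here, no measured pair shows what redistributing the chains between the two arms of the amine does while the atom count stays the same; the one step in hand concerns adding atoms, which compound 3 does not do. The expectation for compound 3 is therefore no step beyond the scatter, a 1.3-fold lower number from compound 2 to compound 3 (0.12 log units; within the scatter), with the range allowing a somewhat lower number. The estimate for compound 3 in this assay is 2.8 nM, with a range from 1 nM to 8 nM.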

Compound 3, half-maximal inhibitory concentration: 1.72 nM
Compound 3: the middle estimate sits 1.6-fold (0.21 log units) above what was measured; measured number inside the range.
By their numbers in this assay, from the lowest: compounds 1 and 3 (each within the scatter of the next); then compound 2.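

In this assay the number of chain atoms on the amine does not alone set the result: a 2.2-fold lower number from compound 2 to compound 3 (0.34 log units; beyond the scatter) comes with butyl(ethyl)amino in place of dipropylamino, the same atoms joined differently. Extending only one arm of the diethylamino group gives a 1.4-fold higher number from compound 1 to compound 3 (0.16 log units; within the scatter) as the ethyl goes on, so among these three compounds the added chain separates compound 2 from compound 1 but does not separate compound 3 from compound 1. Nothing available bears on why the arrangement of the two arms matters. Still open, as far as these compounds go, is how the series responds to a longer pair of arms such as dibutylamino, or to a cyclic amine such as morpholine. Also open, from the compounds shown here alone, is the effect of a branched arm such as isopropyl, or of an ether-bearing arm such as 2-methoxyethyl.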